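This account rests on a few compounds, and the source may have more. Where it says the series, first, only, none or still open, it means among the compounds named here.

In a functional assay on MCF7 cells (Homo sapiens) for inhibition (a higher number here means a weaker inhibitor of growth, a lower number a stronger inhibitor of growth), compound 1 (`C=C1C(=O)O[C@H]2[C@H]1CC/C(COC(=O)N1CCC(F)(F)CC1)=C\CC[C@@]1(C)O[C@@H]21`) gives 1620 nM and compound 2 (`C=C1C(=O)O[C@H]2[C@H]1CC/C(COC(=O)NCCN1CCCC1)=C\CC[C@@]1(C)O[C@@H]21`) gives 3910 nM, so compound 2 holds the higher of the two numbers. Going by the values given here, the only measured step, a 2.4-fold higher number from compound 1 to compound 2 (0.38 log units; beyond the scatter), is modest. It puts (2-(pyrrolidin-1-yl)ethyl)amino in place of 4,4-difluoropiperidin-1-yl on a carbonyl carbon.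

Compound 3 (`C=C1C(=O)O[C@H]2[C@H]1CC/C(COC(=O)Nc1n[nH]c(SC)n1)=C\CC[C@@]1(C)O[C@@H]21`) keeps the shared core and changes the same side chain, with 5-(methylsulfanyl)-1H-1,2,4-triazol-3-yl in place of 2-(pyrrolidin-1-yl)ethyl on an amide-type nitrogen. Among the compounds with values here, no measured compound carries an aromatic ring there, so the measured step bears on this change only loosely. It shows that one swap at this part of the molecule moved the number modestly, and that is the size of change expected here. The direction is poorly defined, with a slight lean toward a lower number, as compound 1 at 1620 nM is the only other reference point. The expected change is a 1.8-fold lower number from compound 2 to compound 3 (0.25 log units; within the scatter), and it is uncertain in sign. For compound 3, the estimated value in this assay is 2200 nM, with an expected range from 750 nM to 6500 nM.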

Compound 3, concentration for 50% growth inhibition: 1330 nM
Beside the measured number, compound 3's estimate is 1.7-fold (0.22 log units) above it; low and high end bracket the measured number.
By their numbers in this assay, from the lowest: compounds 3 and 1 (each within the scatter of the next); then compound 2.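

In this assay, 5-(methylsulfanyl)-1H-1,2,4-triazol-3-yl in place of 2-(pyrrolidin-1-yl)ethyl on an amide-type nitrogen gives a 2.9-fold lower number from compound 2 to compound 3 (0.47 log units; beyond the scatter), a modest step that shows this position can also carry a five-membered aromatic ring with 3 hetero atoms and give a stronger inhibitor of growth than the 2-(pyrrolidin-1-yl)ethyl group does. Set against the other carbamate, the change reads as a 1.2-fold lower number from compound 1 to compound 3 (0.09 log units; within the scatter), so (5-(methylsulfanyl)-1H-1,2,4-triazol-3-yl)amino and 4,4-difluoropiperidin-1-yl on a carbonyl carbon cannot be told apart in this read-out. Going by these compounds alone, two very different groups therefore land level, and compound 2 alone stands apart from them, which the single earlier step could not show.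

The compounds shown leave open whether the methylsulfanyl group on the aromatic ring contributes to the step at all, and whether a plain phenyl ring, a carboxylic acid or a longer chain carrying an amine on the same nitrogen would fall with compound 3 or with compound 2. Nothing given here offers any explanation for these steps.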